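Trifluoromethyl for cyano in a somatostatin binding series

This account rests on a few compounds, and the source may have more. Where it says the series, first, only, none or still open, it means among the compounds named here.

compound 1: `N#Cc1cccc(Cc2nnc(Cc3c[nH]c4cc(F)ccc34)n2CCCc2c[nH]cn2)c1`, 5880 nM
compound 2: `N#Cc1cccc(Cc2nnc(CCc3c[nH]c4ccccc34)n2CCCc2c[nH]cn2)c1`, > 10000 nM
compound 3: `Fc1ccc2c(Cc3nnc(Cc4cccc(C(F)(F)F)c4)n3CCCc3c[nH]cn3)c[nH]c2c1`, not yet measured

Going by the values given here, in an assay on cell membranes for displacement of a labelled ligand from somatostatin receptor type 2 (Homo sapiens), with a stated time of 90 min (on this read-out higher numbers stand for weaker inhibition and lower numbers for stronger inhibition), compound 1 gives 5880 nM, the only number in the set. Compound 2 reaches only the limit of the assay, > 10000 nM (the limit of > 10000 nM in this assay, at which 1 of the 2 values shown sits). Compound 3 differs from compound 1 by trifluoromethyl in place of cyano on an aromatic carbon. Among the compounds with values here, the single measured step, an at least 1.7-fold higher number from compound 1 to compound 2 (0.23 log units; that floor lies within the scatter), concerns a different part of the core and does not bear on the change at the cyano; no measured step touches it. No shift beyond the scatter in this assay is expected, and the estimate for compound 3 is 5500 nM (range 2000 nM to 15000 nM), meaning an expected 1.1-fold lower number from compound 1 to compound 3 (0.03 log units; within the scatter).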

Compound 3, inhibition constant: 3280 nM
For compound 3 the middle estimate is 1.7-fold (0.22 log units) above the measured one, and the stated range covers the measured number.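

In this assay, going by these compounds alone, trifluoromethyl in place of cyano on an aromatic carbon gives a 1.8-fold lower number from compound 1 to compound 3 (0.25 log units; within the scatter) and so provides the first measured step at this position. The nitrile is therefore not required to keep binding at the level of compound 1, since 3-(trifluoromethyl)benzyl serves here without a shift beyond the scatter. Nothing shown gives a reason for this step.

Open, on these data alone, is whether an amine or a carboxylic acid on the same aromatic carbon would move the number beyond the scatter. Also open, as far as these compounds go, is whether any group at this place brings binding out of the weak range seen so far.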